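Bromophenyl to isopropylphenyl on the anilino nitrogen

The source may report more compounds than this note shows. Statements on the series, on what has been measured and on what is new or still open speak of the compounds shown alone.

Measured compounds:
compound 1 `CNC(=O)c1ccccc1Oc1nc(Nc2ccc(Br)cc2)ncc1Br` — 36600 nM
compound 2 `CNC(=O)c1ccccc1Oc1nc(Nc2ccccc2F)ncc1Br` — a limit of the assay, > 50000 nM
compound 3 `CNC(=O)c1ccccc1Oc1nc(Nc2cccc(C(F)(F)F)c2)ncc1Br` — 32800 nM

In a functional assay on MDA-MB-468 cells (Homo sapiens) for antiproliferative activity, read by MTT assay, with a stated time of 24 h (on this read-out lower numbers stand for stronger inhibition and higher numbers for weaker inhibition), compound 1 gives 36600 nM. Compound 3 gives 32800 nM, which sits within the scatter of compound 1. Compound 2 reaches only a limit of the assay, > 50000 nM. Among the two numbers shown, compound 1 stands highest, with compound 3 close beside it.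

For the measured compounds named here, the only measured step at this position runs an at least 1.3-fold higher number from compound 1 to compound 2 (0.13 log units; that floor lies within the scatter); its floor lies within the scatter, and the limit of > 50000 nM in this assay, at which 1 of the 3 values shown sits, is reached there.

Compound 4 `CNC(=O)c1ccccc1Oc1nc(Nc2cccc(C(C)C)c2)ncc1Br` is not yet measured. It differs from compound 1 thus: 3-isopropylphenyl in place of 4-bromophenyl on a nitrogen on an aromatic ring. Compound 3, carrying a 3-trifluoromethylphenyl at the same place, stays within the scatter of compound 1, and the step to compound 2 is uninformative in size. Compound 4 is therefore expected to show no step beyond the scatter, a 1.1-fold lower number from compound 1 to compound 4 (0.03 log units; within the scatter), giving an estimated 34000 nM with a range from 15000 nM to 60000 nM.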

Compound 4, half-maximal inhibitory concentration: 19500 nM
Compound 4: the middle estimate sits 1.7-fold (0.24 log units) above what was measured; the measured number falls inside the stated range.
By their numbers in this assay, from the lowest: compounds 4, 3 and 1 (each within the scatter of the next). At a limit, above all of these: compound 2.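

In this assay, the earlier groups on this nitrogen all carried bromine or fluorine, and compound 4 shows that an all-carbon 3-isopropylphenyl fits the same range: the data give a 1.9-fold lower number from compound 1 to compound 4 (0.27 log units; within the scatter) and a 1.7-fold lower number from compound 3 to compound 4 (0.23 log units; within the scatter). For the compounds shown here, the only step here that clears the scatter is an at least 2.5-fold lower number from compound 2 to compound 4 (0.40 log units; beyond the scatter), which separates compound 4 from the 2-fluorophenyl of compound 2 by at least that floor. Compound 2 stands at a limit of the assay, not at a number: the limit of > 50000 nM in this assay, at which 1 of the 4 values shown sits.

From the compounds shown here alone, it remains open whether an amine or a carboxylic acid on this phenyl ring, or a longer chain in place of isopropyl, would carry the number beyond the scatter of compound 1. Nor can the effect of the group be told apart from that of its place on the ring, since 4-bromophenyl and 3-isopropylphenyl differ in both.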